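Amide variation in a receptor antagonist series

A few compounds are considered here, and "the series" means these few. Any claim that something is new, unique, unknown or untested is made for them only; others in the source may bear on it.

Compound 1 `CC1(C)CC2CC(C)(CN2C(=O)c2sc(-c3ccc(S(C)(=O)=O)c([N+](=O)[O-])c3)nc2C(F)(F)F)C1`: 2100 nM
Compound 2 `CC1Cc2ccccc2N1C(=O)c1sc(-c2ccc(S(C)(=O)=O)c([N+](=O)[O-])c2)nc1C(F)(F)F`: 5200 nM

Going by the values given here, in a functional assay for antagonist activity at thyroid hormone receptor beta (Homo sapiens), read by fluorescence polarization, with a stated time of 3 h (on this read-out higher numbers stand for weaker inhibition and lower numbers for stronger inhibition), compound 2 stands highest of the two numbers; compound 1 gives 2100 nM, and the one measured step, a 2.5-fold higher number from compound 1 to compound 2 (0.39 log units; beyond the scatter), is modest though beyond the scatter.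

Compound 3 `CN(Cc1cccc(F)c1)C(=O)c1sc(-c2ccc(S(C)(=O)=O)c([N+](=O)[O-])c2)nc1C(F)(F)F` differs from compound 2 by (3-fluorobenzyl)(methyl)amino in place of 2-methyl-2,3-dihydro-1H-indol-1-yl on a carbonyl carbon. The group that leaves holds a five-membered non-aromatic ring with one hetero atom fused to a six-membered aromatic ring of carbon only; the group that enters holds a single six-membered aromatic ring of carbon only and a fluorine. Among the compounds with values here, no measured step covers this exchange. Within the data shown here, the step from compound 1 to compound 2 concerns a different group on the same carbonyl carbon and shows only that changing that group moves the number by a modest amount; it gives no direction for the present change. The expected step is therefore a 1.0-fold lower number from compound 2 to compound 3 (0.02 log units; within the scatter), near no change beyond the scatter, and compound 3 is estimated at 5000 nM, within a range from 1500 nM to 16000 nM.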

Compound 3, half-maximal inhibitory concentration in the thyroid hormone receptor beta assay: 2800 nM
Estimate against measurement, compound 3: 1.8-fold (0.25 log units) above, within the range that was stated.
By their numbers in the thyroid hormone receptor beta assay, from the lowest: compounds 1, 3 and 2 (each within the scatter of the next, the first and the last beyond it).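

At this carbonyl carbon, in the thyroid hormone receptor beta assay, (3-fluorobenzyl)(methyl)amino, with its single ring, stands level with both fused-ring groups: a 1.9-fold lower number from compound 2 to compound 3 (0.27 log units; within the scatter), and a 1.3-fold higher number from compound 1 to compound 3 (0.12 log units; within the scatter). In a physicochemical assay for solubility, in phosphate buffer, at pH 7.4 (on this read-out lower numbers stand for lower solubility and higher numbers for higher solubility), compound 2 gives 400 nM and compound 3 gives 1200 nM. The exchange from 2-methyl-2,3-dihydro-1H-indol-1-yl to (3-fluorobenzyl)(methyl)amino therefore separates this pair on solubility but not on inhibition: the measured solubility of compound 2, 400 nM, and of compound 3, 1200 nM, a 3.0-fold higher number (0.48 log units; beyond the scatter)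

The compounds shown do not separate the contribution of the fluorine from that of the rest of (3-fluorobenzyl)(methyl)amino. Also open, going by these compounds, is how a morpholine, or a benzyl group carrying a carboxylic acid, on this carbonyl carbon would stand on inhibition and solubility.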